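Amine variation on the acrylamide side chain

The source may hold more compounds than are shown below. What is called first, only, known or untested is meant among the compounds shown, and "the series" means these compounds.

Compound 1 `CC/C=C/C(=O)Nc1cc2c(N3CCc4ccccc43)ncnc2cc1OC` gives 4030 nM in a functional assay on MCF7 cells (Homo sapiens) for antiproliferative activity, read by MTT assay, with a stated time of 72 h; a higher number here means a weaker inhibitor, a lower number a stronger inhibitor. Compound 2 `COc1cc2ncnc(N3CCc4ccccc43)c2cc1NC(=O)/C=C/CN(C)C` gives 3370 nM in this assay, and the change a 1.2-fold lower number from compound 1 to compound 2 (0.08 log units; within the scatter) leaves the two compounds within the scatter of one another, so compound 2 holds the lower of the two numbers without standing apart. Compound 3 `COc1cc2ncnc(N3CCc4ccccc43)c2cc1NC(=O)/C=C/CN1CCN(C)CC1` carries 4-methylpiperazin-1-yl in place of dimethylamino on a saturated chain carbon bound to a double-bonded chain carbon. Within the data shown here, the only step bearing on this place, a 1.2-fold lower number from compound 1 to compound 2 (0.08 log units; within the scatter), was small, so no step beyond the scatter is expected from compound 2 to compound 3 a 1.1-fold lower number from compound 2 to compound 3 (0.05 log units; within the scatter). Compound 3 is therefore estimated at 3000 nM, with a range from 1200 nM to 7500 nM.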

Compound 3, half-maximal inhibitory concentration: 6430 nM
Compound 3: the middle estimate sits 2.1-fold (0.33 log units) below what was measured, and the stated range covers the measured number.
By their numbers in this assay, from the lowest: compounds 2, 1 and 3 (each within the scatter of the next).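

At this saturated chain carbon bound to a double-bonded chain carbon, a six-membered non-aromatic ring now enters, and this assay shows two further steps (a 1.9-fold higher number from compound 2 to compound 3 (0.28 log units; within the scatter)) and (a 1.6-fold higher number from compound 1 to compound 3 (0.20 log units; within the scatter)), both within the scatter. Even with 4-methylpiperazin-1-yl in place of dimethylamino or of methyl, the three side chains do not separate at this position. Nothing measured alongside these numbers offers an explanation for them.

Going by these compounds, whether a morpholine ring, a carboxylic acid or a longer chain carrying the amine would also leave the number unmoved stays open.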